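The source may report more compounds than this note shows. Statements on the series, on what has been measured and on what is new or still open speak of the compounds shown alone.

Values in a functional assay on A-375 cells (Homo sapiens) for antiproliferative activity, read by MTT assay, with a stated time of 72 h (a lower number here means a stronger inhibitor, a higher number a weaker inhibitor), each one a limit of the assay and not a number:
- compound 1 (`COc1cccc(N2C(=O)COc3ccc(-c4cnc(Cl)c(NS(=O)(=O)c5ccc(F)cc5)c4)cc32)c1`): > 40000 nM
- compound 2 (`O=C1COc2ccc(-c3cnc(Cl)c(NS(=O)(=O)c4ccc(F)cc4)c3)cc2N1`): > 40000 nM
- compound 3 (`CC(C)N1C(=O)COc2ccc(-c3cccc(NS(=O)(=O)c4ccc(F)cc4)c3)cc21`): > 40000 nM

For the measured compounds named here, the series so far offers only this: (the limit of > 40000 nM in this assay, at which 3 of the 3 values shown sit). Compound 3 has no number, and its standing is a limit alone.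

The next step leads to compound 4 (`O=C1COc2ccc(-c3cccc(NS(=O)(=O)c4ccc(F)cc4)c3)cc2N1c1ccccc1`), with phenyl in place of isopropyl on an amide-type nitrogen in a ring.

Going by the values given here, one measured step touches an amide-type nitrogen in a ring, namely (a step that the two limits leave unreadable from compound 1 to compound 2), with hydrogen in place of 3-methoxyphenyl. Its size cannot be read, so it gives no figure to carry over. Compound 1 does show that an aromatic group on that nitrogen can go with a limit value (> 40000 nM), although the core of compound 1 is not that of compound 4.

No large gain in this assay is therefore expected. If a number appears at all, only a modest move towards stronger inhibition is expected, and a limit result remains the likeliest outcome. The estimated step is (an at least 1.3-fold lower number from compound 3 to compound 4 (0.12 log units; that floor lies within the scatter)). The expected value for compound 4 is (30000 nM), with an estimated range of (8000 nM) to (40000 nM).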

Compound 4, half-maximal inhibitory concentration: > 40000 nM
Compound 4: only a limit was reported; the forecaster's own chance of this, stated with the estimate: 70%; at least 1.3-fold (0.12 log units) between middle value and limit.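

In this assay compound 4 gives > 40000 nM, a limit of the assay and not a number. Compound 3 is also known only as a limit, and the step from isopropyl to phenyl between compound 3 and compound 4 cannot be read. The compounds shown leave open whether any group on that amide-type nitrogen of the shared core gives a measurable value.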